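Fluoro in place of methoxy on the cinnamamide ring

The source may hold more compounds than are shown below. What is called first, only, known or untested is meant among the compounds shown, and "the series" means these compounds.

Compound 1 `COc1ccc(C(=O)c2cc(OC)c(OC)c(OC)c2)cc1NC(=O)/C=C/c1ccc(F)cc1` and compound 2 `COc1cc(/C=C/C(=O)Nc2cc(C(=O)c3cc(OC)c(OC)c(OC)c3)ccc2OC)ccc1F` share one core and differ at a single aromatic carbon. In a functional assay on COLO 205 cells (Homo sapiens) for cytotoxicity, read by MTT assay, with a stated time of 72 h (on this read-out higher numbers stand for weaker inhibition and lower numbers for stronger inhibition), compound 1 gives 3400 nM, while compound 2 gives 11800 nM, the highest of the two numbers recorded; the step of a 3.5-fold higher number from compound 1 to compound 2 (0.54 log units; beyond the scatter) came with methoxy in place of hydrogen on an aromatic carbon. Compound 3 `COc1ccc(C(=O)c2cc(OC)c(OC)c(OC)c2)cc1NC(=O)/C=C/c1ccc(F)c(F)c1` is the next step: fluoro in place of methoxy on an aromatic carbon. Among the measured compounds shown here, the one measured step bears on it only in reverse, since it showed that putting the methoxy in raised the number; taking it out again, but now with fluoro rather than hydrogen entering, is expected to bring the number part of the way back toward compound 1. Compound 3 is therefore estimated at 4500 nM, with a likely range of 1500 nM to 14000 nM, meaning an expected step of a 2.6-fold lower number from compound 2 to compound 3 (0.42 log units; beyond the scatter).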

Compound 3, half-maximal inhibitory concentration: 6020 nM
Compound 3: middle estimate off by 1.3-fold (0.13 log units), on the low side; the measured number falls inside the stated range.
By their numbers in this assay, from the lowest: compounds 1, 3 and 2 (each within the scatter of the next, the first and the last beyond it).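

At this aromatic carbon, fluoro adds a third reading in this assay: with fluoro in place of methoxy the result is a 2.0-fold lower number from compound 2 to compound 3 (0.29 log units; within the scatter), and with fluoro in place of hydrogen it is a 1.8-fold higher number from compound 1 to compound 3 (0.25 log units; within the scatter). Neither step can be told apart from the ordinary spread of repeated measurements, so compound 3 cannot be separated from compound 1 or from compound 2, even though those two differ beyond the scatter. No measurement offered here gives a reason for this result.

The compounds shown leave open whether a chloro group, a hydroxyl group, an amine or a longer chain such as ethoxy at this carbon would give a clear step from compound 1. They also leave open whether the same changes would give similar steps on a different core.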